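Swapping One Aryl Group on the Amine Nitrogen

This account rests on a few compounds, and the source may have more. Where it says the series, first, only, none or still open, it means among the compounds named here.

Measured so far:
compound 1 `O=C1C(NC2CCCC2)=CC(=O)c2c1nc1n2[C@H]2OC[C@@H](O)[C@H]2OC1`, > 16000 nM, a limit of the assay and not a number
compound 2 `COc1ccccc1NC1=CC(=O)c2nc3n(c2C1=O)[C@H]1OC[C@@H](O)[C@H]1OC3`, 1630 nM

Of the compounds shown here, two sharing the same core have been tested in a functional assay on MGC-803 cells (Homo sapiens) for inhibition, read by sulforhodamine B assay; on this read-out lower numbers stand for stronger inhibition and higher numbers for weaker inhibition. Compound 1, which carries a cyclopentyl group on the amine nitrogen, reaches only (the limit of > 16000 nM in this assay, at which 1 of the 2 values shown sits). Going by the values given here, compound 2, with a 2-methoxyphenyl group in that place, is the single compound with a real number, 1630 nM, so it stands alone as the point of reference.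

Compound 3 `O=C1C=C(Nc2ccc(I)cc2)C(=O)c2c1nc1n2[C@H]2OC[C@@H](O)[C@H]2OC1` differs from compound 2 in one place: 4-iodophenyl in place of 2-methoxyphenyl on an amine nitrogen. Among the compounds with values here, no pair of measured compounds that differ in a single place is available, so the size of this step cannot be read from any earlier one. Since both compounds keep an aromatic ring on the amine nitrogen, the step is expected to stay close to the scatter, perhaps leaning toward slightly stronger inhibition. Compound 3 is therefore estimated at 1000 nM, with a likely range from 300 nM to 4000 nM, which amounts to an expected step of a 1.6-fold lower number from compound 2 to compound 3 (0.21 log units; within the scatter).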

Compound 3, half-maximal inhibitory concentration: 1400 nM
Beside the measured number, compound 3's estimate is 1.4-fold (0.15 log units) below it; low and high end bracket the measured number.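

Replacing 2-methoxyphenyl with 4-iodophenyl on the amine nitrogen gives, in this assay, a 1.2-fold lower number from compound 2 to compound 3 (0.07 log units; within the scatter), so the two compounds cannot be told apart on this read-out. Going by these compounds alone, until now, compound 2 was the only compound here with a real number, and compound 3 adds a second aromatic ring at this position with a value in the same range, even though the two rings carry different groups and the methoxy oxygen, counted as a hydrogen-bond acceptor, is gone. No measurement shown here explains why these two rings read alike.

As far as these compounds go, it remains open whether the methoxy group and the iodine matter at all, or whether the phenyl ring alone sets this level of inhibition; a plain phenyl group on the same nitrogen would address that, and a 2-iodophenyl or 4-methoxyphenyl group would separate the identity of the added group from where it sits on the ring. Also open, from the compounds shown here alone, is whether a benzyl group, or a phenyl ring carrying a carboxylic acid or an amine, would move the number beyond the scatter in either direction.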